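A Methyl(propyl)amino Arm Added to Compound 3

The compounds below may be only part of what the source reports. "The series", "measured", "known", "first", "only" and "open" are said of these compounds alone.

Compound 3 `CC(=O)Nc1cc(O)ccc1O` was tested in a functional assay on cells (Homo sapiens) for cytotoxicity, read by MTT assay, with a stated time of 48 h (a higher number here means a weaker inhibitor, a lower number a stronger inhibitor), where compound 3 gives 35000 nM. Compound 1 `CN(CC(=O)NC1=CC(=O)C=CC1=O)c1ccccc1` gives 21000 nM in this assay, and these two numbers lie within the scatter of each other, so compound 3 cannot be set above or below compound 1. Compound 2 `CN(CC(=O)Nc1cccc(O)c1)c1ccccc1` reaches only a limit in this assay, > 100000 nM, and this is the limit of > 100000 nM in this assay, at which 1 of the 3 values shown sits. Of the two numbers shown, then, compound 3 sits beside compound 1, with no difference that can be read.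

Compound 4 `CCCN(C)CC(=O)Nc1cc(O)ccc1O` has not yet been measured. It differs from compound 3 by methyl(propyl)amino in place of hydrogen on a saturated chain carbon bound to a carbonyl carbon. Among the measured compounds shown here, no pair of measured compounds shows the effect of such a change, so the expectation rests on compound 3 alone, and no step beyond the scatter is foreseen. Compound 4 is therefore expected to give about 30000 nM in this assay, somewhere between 8000 nM and 100000 nM. That corresponds to an expected 1.2-fold lower number from compound 3 to compound 4 (0.07 log units; within the scatter), a shift not beyond the scatter.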

Compound 4, half-maximal inhibitory concentration: 18000 nM
Compound 4: middle estimate off by 1.7-fold (0.22 log units), on the high side, and the stated range covers the measured number.
By their numbers in this assay, from the lowest: compounds 4, 1 and 3 (each within the scatter of the next). At a limit, above all of these: compound 2.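

In this assay, methyl(propyl)amino in place of hydrogen on a saturated chain carbon bound to a carbonyl carbon gives a 1.9-fold lower number from compound 3 to compound 4 (0.29 log units; within the scatter). This is the first single-place step shown at this position, and it shows that a group of 5 heavy atoms, with no ring and no net charge, can enter there without a difference that can be read in this cytotoxicity measure. No measurement shown here bears on this step.

As far as these compounds go, whether a smaller amine such as dimethylamino, a ring amine such as piperidine, or a carboxylic acid at the same position would give a step beyond the scatter remains open. From the compounds shown here alone, it is also open whether a longer chain on the nitrogen would give a step that can be read.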